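The source may report more compounds than this note shows. Statements on the series, on what has been measured and on what is new or still open speak of the compounds shown alone.

In a functional assay on A549 cells (Homo sapiens) for antiproliferative activity, read by MTT assay, with a stated time of 48 h (on this read-out higher numbers stand for weaker inhibition and lower numbers for stronger inhibition), compound 1 `COc1cc(-c2cccc3nc(-c4ccccc4)oc23)cc(OC)c1OC` gives 20300 nM. Among the compounds with values here, compound 2 `COc1cc(-c2cccc3nc(-c4cccc(F)c4)oc23)cc(OC)c1OC` gives 2600 nM, the lowest of the two numbers so far. Within the data shown here, the only measured step is a 7.8-fold lower number from compound 1 to compound 2 (0.89 log units; beyond the scatter), with fluoro in place of hydrogen on an aromatic carbon.

Compound 3 `COc1cc(-c2cccc3nc(-c4ccc(Cl)cc4)oc23)cc(OC)c1OC` has not yet been measured in this assay. It differs from compound 2 by having 4-chlorophenyl in place of 3-fluorophenyl on an aromatic carbon. Among the measured compounds shown here, both the halogen and its place on the phenyl ring change at once, and no measured compound separates these two changes.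

For the measured compounds named here, the single measured step replaces hydrogen with a halogen, not one halogen with another, so it is only a loose guide here. Compound 3 keeps a halogen on that ring, as compound 2 does at 2600 nM, so a return to the level of compound 1 at 20300 nM is not expected. No step beyond the scatter is expected, though the uncertainty is wide in both directions. The estimated step is a 1.2-fold higher number from compound 2 to compound 3 (0.06 log units; within the scatter). For compound 3 the expected value is 3000 nM, with an estimated range from 800 nM to 11000 nM.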

Compound 3, half-maximal inhibitory concentration: 5600 nM
Beside the measured number, compound 3's estimate is 1.9-fold (0.27 log units) below it; the range from low to high includes it.
By their numbers in this assay, from the lowest: compound 2; then compound 3; then compound 1.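

In this assay, chloro in place of hydrogen gives a 3.6-fold lower number from compound 1 to compound 3 (0.56 log units; beyond the scatter) and so shows that fluoro is not the only halogen on this phenyl ring that comes with a lower number than the unsubstituted ring of compound 1. The new comparison between the two halogen-bearing compounds shows something further: these rings are not interchangeable, as 4-chlorophenyl in place of 3-fluorophenyl gives a 2.2-fold higher number from compound 2 to compound 3 (0.33 log units; beyond the scatter) and this modest step lies beyond the usual scatter. Both the halogen and its place on the ring change together in that step, and nothing available separates those two changes or explains either step.

Fluoro and chloro each appear at only one place on the phenyl ring in the compounds shown, so the effect of changing the halogen while keeping its place fixed remains open, as does the effect of moving one halogen while keeping its identity. Also open, from the compounds shown here alone, is how this ring would respond to groups other than halogens, such as a methoxy group, a nitrile, an amine or a carboxylic acid.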